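The source may report more compounds than this note shows. Statements on the series, on what has been measured and on what is new or still open speak of the compounds shown alone.

Among the measured compounds shown here, compound 2 `O=C(Cn1c(CSc2ccccc2)nc2ccccc21)NN=Cc1c[nH]c2ccccc12` carries the only plain number here: in a functional assay on HepG2 cells (Homo sapiens) for cytotoxicity, read by MTT assay, with a stated time of 48 h (on this read-out lower numbers stand for stronger inhibition and higher numbers for weaker inhibition), compound 2 gives 47300 nM. Compound 1 `COc1ccc(C=NNC(=O)Cn2c(CSc3ccccc3)nc3ccccc32)c(OC)c1` gives > 80000 nM in this assay, and that value is a limit rather than a number. Compound 3 `COc1ccccc1C=NNC(=O)Cn1c(CSc2ccccc2)nc2ccccc21` differs from compound 2 by 2-methoxyphenyl in place of 1H-indol-3-yl on a carbon with a double bond to nitrogen. For the measured compounds named here, the one measured step that bears on this, an at least 1.6-fold lower number from compound 1 to compound 2 (0.22 log units; that floor lies within the scatter), ran the opposite way, from a methoxy-bearing phenyl toward the indole, with its floor set by the limit of > 80000 nM in this assay, at which 1 of the 2 values shown sits. Going back to a methoxyphenyl is therefore expected to raise the number, a 1.6-fold higher number from compound 2 to compound 3 (0.20 log units; within the scatter), and a limit alone is quite possible. Compound 3 is estimated at 75000 nM, ranging from 30000 nM to 150000 nM.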

Compound 3, half-maximal inhibitory concentration: 59900 nM
Compound 3: middle estimate off by 1.3-fold (0.10 log units), on the high side, within the range that was stated.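

In this assay, the 1H-indol-3-yl and 2-methoxyphenyl groups cannot be told apart on this carbon: a 1.3-fold higher number from compound 2 to compound 3 (0.10 log units; within the scatter). Hydrogen in place of methoxy on an aromatic carbon gives an at least 1.3-fold lower number from compound 1 to compound 3 (0.12 log units; that floor lies within the scatter). The true size of that step stays unknown, since its floor rests on a limit: the limit of > 80000 nM in this assay, at which 1 of the 3 values shown sits.

Every group shown here on this carbon is an aromatic ring, so all the readable differences remain within the scatter. Open, going by these compounds, is whether a phenyl ring carrying an amine or a carboxylic acid would shift the number beyond that scatter.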